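The source may report more compounds than this note shows. Statements on the series, on what has been measured and on what is new or still open speak of the compounds shown alone.

Three compounds with a shared core, each carrying an aryl sulfone linked through a benzylic amide, have been measured in an ADME assay on microsomes from liver (Mus musculus) for metabolic stability, read by LC-MS, with a stated time of 30 min, tested at 1 uM; on this read-out higher numbers stand for a more stable compound and lower numbers for a less stable compound. Compound 1, `O=C(NCc1ccc(S(=O)(=O)c2cc(F)cc(F)c2)cc1)c1cc2ccncc2o1`, gives 12%. Compound 3, `O=C(NCc1ccc(S(=O)(=O)c2ccccc2)cc1)c1cc2ccncc2s1`, gives 21%. Compound 2, `O=C(NCc1ccc(S(=O)(=O)c2ccc(F)c(F)c2)cc1)c1cc2cnccc2[nH]1`, gives 58%, the highest of the three numbers; its nearest neighbour is compound 3, which lies below it by more than the scatter of this assay, and compound 1 lies lower still, also beyond the scatter.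

The step under consideration leads from compound 2 to compound 4, `O=C(NCc1ccc(S(=O)(=O)c2cccc(F)c2)cc1)c1cc2cnccc2[nH]1`, which is still to be measured in this assay. The change is a single one on the 3,4-difluorophenyl ring: hydrogen in place of fluoro on an aromatic carbon. Only one heavy atom is removed, and the rest of the molecule is untouched.

Among the measured compounds shown here, no pair of compounds among those measured differs in just one place, so no measured step can serve as a direct guide here. Given how little of the structure changes, a step of modest size, if any, is expected, and it is estimated to go slightly downward: a number 10 percentage points lower from compound 2 to compound 4 (within the scatter). Compound 4 is accordingly expected to show about 48% in this assay, with a range from 25% to 70%.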

Compound 4, percent of the compound remaining: 44%
The estimate for compound 4 lay 4 percentage points above the measured number, within the range that was stated.
By their numbers in this assay, from the lowest: compounds 1 and 3 (each within the scatter of the next); then compound 4; then compound 2.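

Hydrogen in place of fluoro, on an aromatic carbon ortho to a fluoro group and para to a large group, turns 3,4-difluorophenyl into 3-fluorophenyl and gives in this assay a number 14 percentage points lower from compound 2 to compound 4 (beyond the scatter), the first step here that isolates a single place in the molecule. It shows that this position is not indifferent to the read-out: the loss of one fluorine atom, with the rest of the structure unchanged, is enough for a modest step, and the fluoro group that remains on the ring does not hold the number at the level of the difluorinated compound. Nothing at hand gives a measured reason for this step, so it stands as an observation about these two compounds alone.

Open, on these data alone, is whether the step belongs to fluoro in particular, since a single pair cannot tell how chloro, methoxy, a nitrile or an amine at the same position would read out. Equally open, as far as these compounds go, is whether the same change would give a step of similar size on the cores of compound 1 and compound 3, or with the remaining fluoro group replaced by hydrogen as well.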